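The source may report more compounds than this note shows. Statements on the series, on what has been measured and on what is new or still open speak of the compounds shown alone.

Measured compounds in the series:

Compound 1, `CCC(=O)N1N=C(c2ccc(C)cc2)CC1c1ccc(OC)cc1`: in an assay on isolated protein for inhibition of Amine oxidase [flavin-containing] B (Bos taurus) (a lower number here means a stronger inhibitor, a higher number a weaker inhibitor), compound 1 gives 100000 nM.
Compound 2, `CCC(=O)N1N=C(c2ccc(OC)cc2)CC1c1ccc(F)cc1`: in this assay compound 2 gives 100000 nM.

Compound 2 stands level with compound 1 at the digits shown; the two values lie within the scatter of each other, and nothing distinguishes them in this assay.

Compound 3 is `CCC(=O)N1N=C(c2ccc(OC)cc2)CC1c1ccc(OC)cc1`. It differs from compound 2 by methoxy in place of fluoro on an aromatic carbon; the same difference, cut one bond further out, reads 4-fluorophenyl to 4-methoxyphenyl. Among the measured compounds shown here, no step between measured compounds covers this change. Both measured compounds sit at the same weak level in this assay, so no step beyond the scatter is expected here, in either direction. Compound 3 is estimated at 100000 nM in this assay, range 30000 nM to 100000 nM. The expected step from compound 2 to compound 3 is no change at the digits printed from compound 2 to compound 3 (within the scatter).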

Compound 3, half-maximal inhibitory concentration: 2400 nM
Estimate against measurement, compound 3: 42-fold (1.62 log units) above, outside the stated range (below it).
By their numbers in this assay, from the lowest: compound 3; then compounds 1 and 2 (each within the scatter of the next).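

In this assay, methoxy on both aromatic rings separates compound 3 from the earlier pair: the series moves with a 42-fold lower number from compound 2 to compound 3 (1.62 log units; beyond the scatter) and with a 42-fold lower number from compound 1 to compound 3 (1.62 log units; beyond the scatter). Compounds 1 and 2 each carry one methoxy group, on different rings, and sit level, so among these three compounds a single methoxy group alone does not lower the number, while the second one, entering at either place, does. No measurement at hand explains the drop.

Still open, as far as these compounds go, is whether a hydroxyl, an ethoxy group or an amine in place of either methoxy group would keep the lower number. The compounds shown also leave open whether the change holds with a longer chain on the carbonyl of the shared core.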